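Lipophilicity across the shared oxazolidinone series

The source may report more compounds than this note shows. Statements on the series, on what has been measured and on what is new or still open speak of the compounds shown alone.

Working notes on the series. Compound 1 `CC(=O)NC[C@H]1CN(c2ccc(OC[C@H](O)CNc3ccccc3)c(F)c2)C(=O)O1` carries a 2-anilino-1-hydroxyethyl group on a saturated chain carbon bound to an oxygen on an aromatic ring. Going by the values given here, in a physicochemical assay for lipophilicity, read by HPLC (on this read-out higher numbers stand for higher lipophilicity and lower numbers for lower lipophilicity), compound 1 gives 0.59, the lower of the two numbers measured so far. Among the compounds with values here, compound 2 `CC(=O)NC[C@H]1CN(c2ccc(OC[C@H](O)CNc3cc(C(F)(F)F)cc(C(F)(F)F)c3)c(F)c2)C(=O)O1`, which carries two trifluoromethyl groups on the six-membered aromatic ring of carbon only, gives in this assay a reading of 3.01, a gap beyond the usual scatter; the two compounds differ in more than one place, so no single step is drawn between them.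

Compound 3 `CC(=O)NC[C@H]1CN(c2ccc(OC[C@@H]3CNC(=O)O3)c(F)c2)C(=O)O1` has not yet been measured in this assay. Its change from compound 1 is 2-oxo-1,3-oxazolidin-5-yl in place of 2-anilino-1-hydroxyethyl on a saturated chain carbon bound to an oxygen on an aromatic ring. The group that leaves holds the six-membered aromatic ring of carbon only and two hydrogen-bond donors; the group that enters is a five-membered non-aromatic ring with two hetero atoms and one hydrogen-bond donor, four heavy atoms fewer.

For compound 3 the step of a number 1.09 log units lower from compound 1 to compound 3 (beyond the scatter) is expected to be downward and beyond the scatter. Compound 3 is estimated at -0.5 in this assay, within a range of -1.2 to 0.2.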

Compound 3, partition coefficient: 0.01
Estimate against measurement, compound 3: 0.51 log units below; measured number inside the range.
By their numbers in this assay, from the lowest: compound 3; then compound 1; then compound 2.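

On a saturated chain carbon bound to an oxygen on an aromatic ring, the series now has its first single-place comparison: in this assay, placing 2-oxo-1,3-oxazolidin-5-yl in place of 2-anilino-1-hydroxyethyl gives a number 0.58 log units lower from compound 1 to compound 3 (beyond the scatter) as the size of this change. The step is one exchange with several parts, since the six-membered aromatic ring of carbon only leaves, a five-membered non-aromatic ring with 2 hetero atoms enters, and the counts of heavy atoms and hydrogen-bond donors both fall, and a single step cannot assign the shift to any one of these parts. No measurement at hand bears on the origin of this step.

The compounds shown leave open how much of the step belongs to the loss of the aromatic ring and how much to the ring that enters, a question that a simple primary amine, a carboxylic acid or a longer alkyl chain on the same carbon could help to divide. Going by these compounds alone, they also leave open whether the step would keep its size and direction on a core carrying other substituents, as no second pair with this same exchange stands.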